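This account rests on a few compounds, and the source may have more. Where it says the series, first, only, none or still open, it means among the compounds named here.

Compound 1: `COC1Cc2sccc2C2(CCN(CCCc3ccccc3)CC2)O1`, 2.4 nM in an assay on membranes from brain for displacement of a labelled ligand from Sigma non-opioid intracellular receptor 1 (Cavia porcellus); a higher number here means a weaker inhibitor, a lower number a stronger inhibitor
Compound 2: `COc1ccc(CN2CCC3(CC2)OC(OC)Cc2sccc23)cc1`, 2.2 nM

Among these two numbers in this assay compound 2 holds the lower one, though only by a 1.1-fold lower number from compound 1 to compound 2 (0.04 log units; within the scatter), which is within the scatter. Compound 3 is `COC1Cc2sccc2C2(CCN(CC=C(C)C)CC2)O1`; it differs from compound 2 by 2-methylprop-1-en-1-yl in place of 4-methoxyphenyl on a saturated chain carbon bound to an amine nitrogen in a ring. Going by the values given here, the only measured step that bears on this position is a 1.1-fold lower number from compound 1 to compound 2 (0.04 log units; within the scatter), where two different groups on this carbon gave much the same result. Among the compounds with values here, no measured compound carries a group without a ring here, so the expectation is a modest weakening, a 2.7-fold higher number from compound 2 to compound 3 (0.44 log units; beyond the scatter). Compound 3 is estimated at 6 nM, with a range from 1.5 nM to 25 nM.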

Compound 3, inhibition constant: 1 nM
The estimate for compound 3 lay 6.0-fold (0.78 log units) above the measured number; measured number outside the range, below it.
By their numbers in this assay, from the lowest: compound 3; then compounds 2 and 1 (each within the scatter of the next).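

In this assay a group with no ring at all does well on this saturated chain carbon: 2-methylprop-1-en-1-yl gives a 2.2-fold lower number from compound 2 to compound 3 (0.34 log units; beyond the scatter) and a 2.4-fold lower number from compound 1 to compound 3 (0.38 log units; beyond the scatter), both modest steps but beyond the scatter. Among these compounds, then, neither 4-methoxyphenyl nor phenethyl is needed here for a low number. Nothing measured here explains the gain. On these data alone, whether a saturated chain of the same size, a longer chain or a chain carrying an amine would keep the number this low stays open. So does the part played by the double bond.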